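One ether group exchanged on compound 3

This account rests on a few compounds, and the source may have more. Where it says the series, first, only, none or still open, it means among the compounds named here.

Measured so far in an ADME assay on the whole organism (Rattus norvegicus) for pharmacokinetics, using cassette dosing, at a dose of 1 mg/kg by the oral route; on this read-out higher numbers stand for higher oral bioavailability and lower numbers for lower oral bioavailability

- compound 1 `Cc1cc(/N=c2\[nH]c(=O)n(C[C@H](C)C(=O)O)c(=O)n2Cc2ccc(Cl)cc2)ccc1OC(C)C` gives 102%
- compound 2 `Cc1ccc(Cn2c(=O)n(C[C@H](C)C(=O)O)c(=O)[nH]/c2=N\c2ccc(OC(C)C)c(Cl)c2)cc1` gives 73.1%
- compound 3 `C[C@@H](Cn1c(=O)[nH]/c(=N\c2ccc(Oc3cnccn3)cc2)n(Cc2ccc(Cl)cc2)c1=O)C(=O)O` gives 56.5%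

Compound 3 gives 56.5% as the lowest of the three numbers. Compound 2 stands nearest to it with 73.1% and compound 1 furthest with 102% and both gaps lie beyond the usual scatter.

Compound 4 `C[C@@H](Cn1c(=O)[nH]/c(=N\c2ccc(Oc3ccnc(F)c3)cc2)n(Cc2ccc(Cl)cc2)c1=O)C(=O)O` has yet to be read in this assay and differs from compound 3 in one place. On an oxygen on an aromatic ring, 2-fluoropyridin-4-yl stands in place of pyrazin-2-yl 2-fluoropyridin-4-yl in place of pyrazin-2-yl on an oxygen on an aromatic ring and the rest of the structure is unchanged.

Among the measured compounds shown here, no two measured compounds here differ in one place only, so the set gives no direct measure of such an exchange. Compound 3 remains the closest guide, and only a slight rise is expected from it. The expected change is a number 5.5 percentage points higher from compound 3 to compound 4 (within the scatter) and it is estimated to stay within the usual scatter. For compound 4 the estimated value is 62% with an expected range from 38% to 86% as the reading still to come.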

Compound 4, oral bioavailability: 43.2%
Estimate against measurement, compound 4: 18.8 percentage points above; measured number inside the range.
By their numbers in this assay, from the lowest: compound 4; then compound 3; then compound 2; then compound 1.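

In this assay, among the compounds shown here, replacing pyrazin-2-yl with 2-fluoropyridin-4-yl on an oxygen on an aromatic ring gives a number 13.3 percentage points lower from compound 3 to compound 4 (beyond the scatter) and provides the first comparison in this set that changes one place only. It shows that the group on this oxygen matters to the read-out, since the number moves beyond the scatter with the rest of the structure unchanged. Nothing available here bears on what lies behind this step.

The exchange alters the ring's hetero atoms and adds a fluorine together, so the compounds shown cannot apportion the step between those two differences. They also leave open how plain pyridin-4-yl on the same oxygen would read, and whether this step would hold on another part of the series.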